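Swapping the Aryl Ring on the Sulfone of Compound 2

The source may report more compounds than this note shows. Statements on the series, on what has been measured and on what is new or still open speak of the compounds shown alone.

Among the measured compounds shown here, compound 2 `CC1CCN(c2c(S(=O)(=O)c3cccc(Cl)c3)cnc3ccc(Cl)cc23)CC1` is one of two compounds measured in an assay on isolated protein for displacement of a labelled ligand from metabotropic glutamate receptor 5 (Homo sapiens), with a stated time of 60 min, tested at 1 uM; a lower number here means less inhibition, a higher number more inhibition at the concentration tested (going by the name of the read-out); compound 2 gives 92%, the higher of the two numbers, and its only neighbour is compound 1 `Cc1ccc(S(=O)(=O)c2cnc3ccc(Cl)cc3c2N2CCC(C)CC2)cc1C`, which in this assay gives 84%. The gap between them, a number 8 percentage points higher from compound 1 to compound 2 (within the scatter), lies within the scatter, so the two cannot be ranked against each other. Compound 3 `Cc1ccc(S(=O)(=O)c2cnc3ccc(Cl)cc3c2N2CCC(C)CC2)cc1F` has not yet been measured. It differs from compound 2 in one place: 3-fluoro-4-methylphenyl in place of 3-chlorophenyl on a sulfonyl sulfur. For the measured compounds named here, the one measured step that bears on this change is the one on the same sulfonyl sulfur, a number 8 percentage points higher from compound 1 to compound 2 (within the scatter), where a 3-chlorophenyl took the place of a 3,4-dimethylphenyl and the number hardly moved. The present change returns to a ring carrying a methyl, as in compound 1, so the expected step is a number 6 percentage points lower from compound 2 to compound 3 (within the scatter), nothing beyond the scatter. Compound 3 is therefore expected to give about 86% in this assay, within 72% to 96%.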

Compound 3, a percentage reported as inhibition, at one concentration (the size of the read-out at that concentration, not a potency): 68%
Beside the measured number, compound 3's estimate is 18 percentage points above it; the measured number lies below the stated range.
By their numbers in this assay, from the lowest: compound 3; then compounds 1 and 2 (each within the scatter of the next).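

The ring on the sulfonyl sulfur is less forgiving in this assay than the first pair suggested: the earlier swap stayed within the scatter, whereas this one gives a number 24 percentage points lower from compound 2 to compound 3 (beyond the scatter). The closest comparison involves a single substituent, fluoro in place of methyl on an aromatic carbon, and it gives a number 16 percentage points lower from compound 1 to compound 3 (beyond the scatter). A methyl on the ring therefore does not by itself secure a high number, as compound 1 and compound 3 both carry one, and a small substitution on this ring can move the result beyond the scatter.

Nothing available here explains why the number falls. Also open, as far as these compounds go, is how a 3-chloro-4-methylphenyl ring would behave, or a ring carrying a nitrile or a trifluoromethyl in place of the fluoro.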